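Swapping Pyridinyl for Fluorophenyl on a Urea Nitrogen

The compounds below may be only part of what the source reports. "The series", "measured", "known", "first", "only" and "open" are said of these compounds alone.

Compound 1 `O=C(Nc1ccc(F)cc1)N1N=C(c2ccc(Br)cc2)CC1c1ccc(F)cc1`: > 10000 nM
Compound 2 `O=C(Nc1ccncc1)N1N=C(c2ccccc2)CC1c1ccc(F)cc1`: 3090 nM

In an assay on HEK293 cells for inhibition of Voltage-dependent L-type calcium channel subunit alpha-1C (Homo sapiens), read by FLIPR and calcium flux, with a stated time of 3 min (on this read-out lower numbers stand for stronger inhibition and higher numbers for weaker inhibition), compound 2 gives 3090 nM, the only numerical result among the measured compounds. Compound 1 reaches only a limit of this assay, > 10000 nM. Compound 3 `O=C(Nc1ccc(F)cc1)N1N=C(c2ccccc2)CC1c1ccc(F)cc1` differs from compound 2 by 4-fluorophenyl in place of pyridin-4-yl on an amide-type nitrogen. Compound 1 already carries that same group on the same nitrogen and sits at the limit of > 10000 nM in this assay, at which 1 of the 2 values shown sits. Compound 3 is therefore expected to lose potency, with an expected step of a 2.6-fold higher number from compound 2 to compound 3 (0.41 log units; beyond the scatter) beyond the usual scatter. The estimate for compound 3 is 8000 nM, within 2500 nM to 30000 nM.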

Compound 3, half-maximal inhibitory concentration: > 10000 nM
Compound 3 gave a limit, no number; the forecaster's own chance of this, stated with the estimate: 50%; at least 1.2-fold (0.09 log units) between middle value and limit.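

For the compounds shown here, at this amide-type nitrogen the choice of ring clearly counts: 4-fluorophenyl in place of pyridin-4-yl gives an at least 3.2-fold higher number from compound 2 to compound 3 (0.51 log units; beyond the scatter) and leaves pyridin-4-yl as the only group here with a measurable value. Compound 3 gives a limit, not a number, and so does compound 1: the limit of > 10000 nM in this assay, at which 2 of the 3 values shown sit. With two limits, the step for removing bromo cannot be read. Still open, from the compounds shown here alone, is whether pyridin-3-yl or an unsubstituted phenyl on this nitrogen would also give a measurable value. Going by these compounds, whether bromo would change the value of compound 2 is also open.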